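Expected cytotoxicity of compound 4 on liver cells

The source may hold more compounds than are shown below. What is called first, only, known or untested is meant among the compounds shown, and "the series" means these compounds.

Measured so far:
compound 1 `CC(=O)OC[C@H]1CN(c2ccc(-n3cc(-c4ccccn4)cn3)c(F)c2)C(=O)O1` gives > 400 ug/mL in an ADME assay on L02 cells (Homo sapiens) for cytotoxicity, read by MTT assay, with a stated time of 48 h; on this read-out higher numbers stand for weaker inhibition and lower numbers for stronger inhibition
compound 2 `O=C(OC[C@H]1CN(c2ccc(-n3cc(-c4ccccn4)cn3)c(F)c2)C(=O)O1)c1ccccc1` gives > 400 ug/mL in this assay
compound 3 `O=C(NC[C@H]1CN(c2ccc(-n3cc(-c4ccccn4)cn3)c(F)c2)C(=O)O1)C(F)F` gives > 400 ug/mL in this assay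

Each of these three values is a limit of the assay and not a number (the limit of > 400 ug/mL in this assay, at which 3 of the 3 values shown sit). Compound 2 therefore stands only at a limit, with no measured number of its own. Compound 4 `CONC(=O)[C@H]1CN(c2ccc(-n3cc(-c4ccccn4)cn3)c(F)c2)C(=O)O1` differs from compound 2 by methoxycarbamoyl in place of (benzoyloxy)methyl on a saturated ring carbon. The two measured steps that alter the same group, a step that the two limits leave unreadable from compound 1 to compound 2 and a step that the two limits leave unreadable from compound 2 to compound 3, could not be read because every value sits at the limit (the limit of > 400 ug/mL in this assay, at which 3 of the 3 values shown sit). No step beyond the scatter can be expected in either direction. Compound 4 is expected at 400 ug/mL, between 200 ug/mL and 800 ug/mL, most likely again reported as a limit. The expected step is a number no higher from compound 2 to compound 4 (the limit leaves the size open), estimated to lie within the scatter.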

Compound 4, half-maximal inhibitory concentration: > 400 ug/mL
Compound 4 gave a limit, no number; the forecaster's own chance of this, stated with the estimate: 75%; the middle value sits exactly at the limit.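

Compound 4 gives no readable step against compound 1, compound 2 or compound 3, because all four compounds sit at the same limit, which is not a number: the limit of > 400 ug/mL in this assay, at which 4 of the 4 values shown sit.

Going by these compounds, how strongly any of these four compounds inhibits in this assay remains open.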